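The source may report more compounds than this note shows. Statements on the series, on what has been measured and on what is new or still open speak of the compounds shown alone.

Within the data shown here, compound 1 `O=C(Nc1nn[nH]n1)c1cccc(CCc2ccccc2)n1` stands at the top of the three numbers measured so far. In a functional assay on the whole organism for inhibition, with Rattus norvegicus as the target, at a dose of 10 mg/kg by the oral route (a higher number here means a stronger effect of the compound at the dose given, a lower number a weaker effect), compound 1 gives 45%. Compound 3 `O=C(Nc1nn[nH]n1)c1cccnc1` comes nearest, giving 3% in this assay, a gap that lies beyond the usual scatter. Compound 2 `COc1cccnc1C(=O)Nc1nn[nH]n1` lies furthest away, with 0% in this assay, again beyond the scatter. No pair among these three differs in a single place, so no step between measured compounds can be read off; the numbers simply show that only compound 1 has a clear effect at this dose.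

Compound 4 `CCCc1cccc(C(=O)Nc2nn[nH]n2)n1` has not yet been measured. It differs from compound 1 in one place: methyl in place of phenyl on a saturated chain carbon, two bonds along the chain from an aromatic carbon. Among the measured compounds shown here, there is no measured pair of this kind to lean on, so the size of the step is an open question; since the phenyl is lost, a decrease in this assay beyond the scatter is expected rather than a gain. The expected step in this assay comes out as a number 23 percentage points lower from compound 1 to compound 4 (beyond the scatter). Compound 4 is therefore expected to give 22% in this assay, within a range from 3% to 42%.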

Compound 4, a percentage reported as inhibition, in the whole organism at one dose (the size of the read-out at that dose, not a potency): 38%
The estimate for compound 4 lay 16 percentage points below the measured number; the range from low to high includes it.
By their numbers in this assay, from the lowest: compounds 2 and 3 (each within the scatter of the next); then compounds 4 and 1 (each within the scatter of the next).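

Replacing the phenyl with methyl on a saturated chain carbon, two bonds along the chain from an aromatic carbon, gives in this assay a result of a number 7 percentage points lower from compound 1 to compound 4 (within the scatter) and so no readable change. Among these compounds, this is the first single-place comparison, and it shows that, at this dose, the effect seen with compound 1 does not depend on the phenyl: the six-carbon aromatic ring can leave this place and compound 4 still matches it within the scatter.

What the shown compounds leave open is how much of the chain this effect needs, and whether a shorter chain, a longer chain, an amine or a carboxylic acid at this place would keep it. Nothing at hand explains why the phenyl can be lost at this place.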